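The source may hold more compounds than are shown below. What is called first, only, known or untested is meant among the compounds shown, and "the series" means these compounds.

The study concerns an assay on microsomes from intestinal mucosa for inhibition of acyl-CoA:cholesterol acyltransferase (Oryctolagus cuniculus); a lower number here means a stronger inhibitor, a higher number a weaker inhibitor. Among the compounds with values here, compound 1, `CCCCCCCC/C=C\CCCCCCCCOC(=O)Nc1c(OC)cc(OC)cc1OC`, is the only compound here with a measured number: in this assay compound 1 gives 860 nM. Compound 2, `CCCCCCCCCCCCCCCCCCOc1c(C)cccc1C`, carries a long saturated chain on its core. In this assay compound 2 gives > 10000 nM, which is a limit of the assay and not a number. Within the data shown here, compound 2 thus stands at the limit of > 10000 nM in this assay, at which 1 of the 2 values shown sits, so no step between two measured compounds can be drawn from it, and compound 1 and compound 2 can be compared only in that one gives a number and the other a limit. Compound 3, `CCCCCCCCCCCCCCCCCCSc1c(C)cccc1C`, has not yet been measured in this assay. It differs from compound 2 in one place: (2,6-dimethylphenyl)sulfanyl in place of 2,6-dimethylphenoxy on a saturated chain carbon bound to a saturated chain carbon. Compound 3 is expected to stay near the limit. The estimated step is a step that the limit leaves unreadable from compound 2 to compound 3, not beyond the scatter. For compound 3 the estimate in this assay is 12000 nM, within a range from 4000 nM to 40000 nM.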

Compound 3, half-maximal inhibitory concentration: > 10000 nM
Compound 3 was reported as a limit; the forecaster's own chance of this, stated with the estimate: 70%; the middle value lies beyond the limit too.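

Compound 2 and compound 3 both stand at a limit of the assay and not at a number, so no step between them can be read in this assay here: the limit of > 10000 nM in this assay, at which 2 of the 3 values shown sit.

The compounds shown leave open how large any change from exchanging 2,6-dimethylphenoxy for (2,6-dimethylphenyl)sulfanyl is.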